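Dropping the methoxy: compound 1 to compound 4

The source may report more compounds than this note shows. Statements on the series, on what has been measured and on what is new or still open speak of the compounds shown alone.

Of the compounds shown here, three have numbers so far. Compound 1 `COc1ccc(-c2nc3sc(Cc4ccccc4)nn3c2SC#N)cc1` gives 4800 nM in a functional assay on cells (Cancer cell lines, Homo sapiens) for inhibition; on this read-out lower numbers stand for stronger inhibition of growth and higher numbers for weaker inhibition of growth. Compound 2 `Clc1ccc(-c2cn3nc(Cc4ccccc4)sc3n2)cc1` gives 4000 nM in this assay, and compound 3 `O=Cc1c(-c2ccc(F)cc2)nc2sc(CCC3CCCCC3)nn12` gives 11800 nM. Compound 1 thus stands second highest of the three: compound 2 sits within the scatter of it, while compound 3 lies beyond the scatter, on the weaker side. Going by the values given here, no two of these three differ in a single place, so no isolated step is available.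

Compound 4 `N#CSc1c(-c2ccccc2)nc2sc(Cc3ccccc3)nn12` is next to be measured in this assay. It differs from compound 1 by hydrogen in place of methoxy on an aromatic carbon; cut one bond further out, the change reads 4-methoxyphenyl to phenyl. Among the compounds with values here, none of the measured compounds isolates this change, and compounds 2 and 3 differ from compound 1 in several places at once. The expectation is a step from compound 1 to compound 4 of no more than the scatter, with no clear direction. Compound 4 is estimated at 5000 nM, between 2000 nM and 12000 nM in this assay. The step of a 1.0-fold higher number from compound 1 to compound 4 (0.02 log units; within the scatter) implied by this estimate is expected to stay within the scatter.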

Compound 4, concentration for 50% growth inhibition: 7400 nM
For compound 4 the middle estimate is 1.5-fold (0.17 log units) below the measured one; the measured number falls inside the stated range.
By their numbers in this assay, from the lowest: compounds 2, 1, 4 and 3 (each within the scatter of the next, the first and the last beyond it).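

In this assay the series now has its first step between compounds that differ in one place (a 1.5-fold higher number from compound 1 to compound 4 (0.19 log units; within the scatter)), with hydrogen in place of methoxy on an aromatic carbon. At this position, para to a large group, the read-out does not separate 4-methoxyphenyl from phenyl, so the methoxy is not required for growth inhibition of the order seen with compound 1. No measurement on these compounds gives a reason for this.

As far as these compounds go, whether an amine or a carboxylic acid on the same aromatic carbon would give a step beyond the scatter remains open. Also open, from the compounds shown here alone, is whether hydrogen in place of methoxy would read the same with other groups on the shared core.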